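Swapping methyl for 4-methoxyphenyl on the sulfonyl sulfur

The source may hold more compounds than are shown below. What is called first, only, known or untested is meant among the compounds shown, and "the series" means these compounds.

Compound 1 `CS(=O)(=O)N1CCC2(CC1)OOC1(CCCC1)OO2`, compound 2 `CS(=O)(=O)N1CCC2(CC1)OOC1(CCCCCC1)OO2` and compound 3 `CCCCS(=O)(=O)N1CCC2(CC1)OOC1(CCCC1)OO2` each carry a sulfonyl sulfur bound to a sulfonamide nitrogen in a ring, and all three were examined in a functional assay on Huh-7 cells (Homo sapiens) for cytotoxicity, read by MTT assay, with a stated time of 72 h; a lower number here means that less compound is tolerated, a higher number that more compound is tolerated. Compound 1 gives > 100 ug/mL, which is a limit and not a number. Compound 3 gives > 100 ug/mL, again a limit. Compound 2, the starting point here, gives > 100 ug/mL, and this too is only a limit. The whole record so far is the limit of > 100 ug/mL in this assay, at which 3 of the 3 values shown sit.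

Compound 4 `COc1ccc(S(=O)(=O)N2CCC3(CC2)OOC2(CCCCCC2)OO3)cc1` has not yet been measured. It departs from compound 2 as follows: 4-methoxyphenyl in place of methyl on a sulfonyl sulfur. In words, 4-methoxyphenyl stands in place of methyl on a sulfonyl sulfur. Among the measured compounds shown here, the one measured step that bears on this is a step that the two limits leave unreadable from compound 1 to compound 3, where propyl replaces hydrogen on a saturated chain carbon bound to a sulfonyl sulfur. For the measured compounds named here, that step has no readable size, and none of the measured compounds carries an aromatic ring, so the expectation in this assay stays loose and no clear direction can be claimed. The estimated change is a step that the limit leaves unreadable from compound 2 to compound 4. Compound 4 is expected at about 110 ug/mL, within an estimated range of 50 ug/mL to 200 ug/mL.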

Compound 4, half-maximal cytotoxic concentration: > 100 ug/mL
Compound 4: no number, only a limit; the forecaster's own chance of this, stated with the estimate: 65%; the middle value is on the limit's open side.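

The step from compound 2 to compound 4 cannot be read, because both values are limits and not numbers: the limit of > 100 ug/mL in this assay, at which 4 of the 4 values shown sit.

The compounds shown leave open whether 4-methoxyphenyl in place of methyl on a sulfonyl sulfur changes what is tolerated in this assay at all, and where the actual value of each compound lies.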